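An Ester Replaces the Amine Chain on the Aromatic Oxygen

This account rests on a few compounds, and the source may have more. Where it says the series, first, only, none or still open, it means among the compounds named here.

Compound 1, `C#CCOc1cc(/C=C/C(=O)c2ccc(OC)c3c2OC(C)(C)C=C3)ccc1OC`, in a functional assay on A-375 cells (Homo sapiens) for cytotoxicity, read by MTT assay (a higher number here means a weaker inhibitor, a lower number a stronger inhibitor), reads > 10000 nM, which is a limit of the assay rather than a number.
Compound 2, `COc1ccc(/C=C/C(=O)c2ccc(OC)c3c2OC(C)(C)C=C3)cc1OCCCN(C)C`, gives 4100 nM.
Compound 3, `CCC(=O)Oc1cc(/C=C/C(=O)c2ccc(OC)c3c2OC(C)(C)C=C3)ccc1OC`, gives 240 nM.

Among the two numbers in this assay, compound 2 stands highest; its nearest neighbour is compound 3, reached by the step of a 17-fold lower number from compound 2 to compound 3 (1.23 log units; beyond the scatter). Compound 4, `COc1ccc(/C=C/C(=O)Oc2cc(/C=C/C(=O)c3ccc(OC)c4c3OC(C)(C)C=C4)ccc2OC)cc1`, is the next compound to be measured. It differs from compound 2 in one place: (2-(4-methoxyphenyl)ethenyl)carbonyl in place of 3-(dimethylamino)propyl on an oxygen on an aromatic ring.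

Among the compounds with values here, two measured steps bear on this change. Both an at least 41-fold lower number from compound 1 to compound 3 (1.61 log units; beyond the scatter) and a 17-fold lower number from compound 2 to compound 3 (1.23 log units; beyond the scatter) put propanoyl on the aromatic oxygen in place of an alkyl chain, and both were large and downward. Compound 4 likewise carries a carbonyl-bearing group on that oxygen, though a larger one than propanoyl, so a downward step of comparable order is expected, a 10-fold lower number from compound 2 to compound 4 (1.01 log units; beyond the scatter). Compound 4 is therefore estimated at 400 nM in this assay, within a range of 100 nM to 2000 nM.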

Compound 4, half-maximal inhibitory concentration: 2630 nM
For compound 4 the middle estimate is 6.6-fold (0.82 log units) below the measured one; measured number above the stated range.
By their numbers in this assay, from the lowest: compound 3; then compounds 4 and 2 (each within the scatter of the next). At a limit, above all of these: compound 1.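

In this assay, a carbonyl-bearing group on the aromatic oxygen does not by itself secure the low number of compound 3: with 2-(4-methoxyphenyl)ethenyl in place of ethyl on the carbonyl carbon, the step is an 11-fold higher number from compound 3 to compound 4 (1.04 log units; beyond the scatter), while replacing the amine chain gives a 1.6-fold lower number from compound 2 to compound 4 (0.19 log units; within the scatter). What sits on the carbonyl carbon therefore matters at this position, and this larger ester stands level with the amine chain of compound 2. The step from the propargyl ether is an at least 3.8-fold lower number from compound 1 to compound 4 (0.58 log units; beyond the scatter). Compound 1 is recorded only at a limit, so that step is a bound: the limit of > 10000 nM in this assay, at which 1 of the 4 values shown sits.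

Only ethyl and 2-(4-methoxyphenyl)ethenyl appear on the carbonyl carbon, so the shown compounds do not separate the length of that group from the presence of its ring. On these data alone, how a butyl chain or an unsubstituted phenyl ring would read there remains open.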